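The compounds below may be only part of what the source reports. "The series", "measured", "known", "first", "only" and "open" are said of these compounds alone.

Measured compounds:
- compound 1, `CCCCCCCC(=O)O[C@H]1C(=O)OCC1(C)C`; in an assay on isolated protein for inhibition of fatty acid synthase (Mus musculus), read by spectrophotometry, using NADPH, with stated times of 30 min and 3 min, in the presence of a further agent that is not named here (a lower number here means a stronger inhibitor, a higher number a weaker inhibitor), compound 1 gives 20800 nM
- compound 2, `CCCCCCCCCCCC(=O)O[C@H]1C(=O)OCC1(C)C`; in this assay compound 2 gives 15200 nM

Compound 2 stands with compound 1 inside the usual scatter: the step of a 1.4-fold lower number from compound 1 to compound 2 (0.14 log units; within the scatter) is too small to count as a change, so the two ester chains give, in effect, the same number in this assay.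

The next compound, compound 3, `CCCCCCCCCCCCCCCC(=O)O[C@H]1C(=O)OCC1(C)C`, differs from compound 2 by butyl in place of hydrogen on a saturated chain carbon, ten or more bonds along the chain from a carbonyl carbon. Going by the values given here, the only measured step that bears on this is the step from compound 1 to compound 2, which added the same four-carbon piece one rung closer to the carbonyl and gave a 1.4-fold lower number from compound 1 to compound 2 (0.14 log units; within the scatter). With one step of that kind on record, and that step within the scatter, no more than a small movement toward a lower number is expected for the further extension, and the outcome may equally sit flat.

The expected number for compound 3 in this assay is 11000 nM, with a range of 4000 nM to 30000 nM. The implied step a 1.4-fold lower number from compound 2 to compound 3 (0.14 log units; within the scatter) is an estimate that stays within the scatter of a repeat measurement.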

Compound 3, half-maximal inhibitory concentration: 19600 nM
For compound 3 the middle estimate is 1.8-fold (0.25 log units) below the measured one; the measured number falls inside the stated range.
By their numbers in this assay, from the lowest: compounds 2, 3 and 1 (each within the scatter of the next).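

In this assay, butyl in place of hydrogen on a saturated chain carbon, ten or more bonds along the chain from a carbonyl carbon, gives a 1.3-fold higher number from compound 2 to compound 3 (0.11 log units; within the scatter), so a second extension of the chain also stays inside the scatter. The larger change gives a 1.1-fold lower number from compound 1 to compound 3 (0.03 log units; within the scatter), which means that compound 1, compound 2 and compound 3 cannot be ordered and that no trend with chain length can be read from these three compounds. Nothing on hand accounts for this flat result.

Still open, as far as these compounds go, is whether any change to the chain moves the number beyond the scatter, for example a shorter chain than that of compound 1, or a carboxylic acid or an amine carried on the chain. Also open, from the compounds shown here alone, is whether an amide in place of the ester, or a change to the shared core, would separate from these three compounds in this assay, where every chain so far gives, in effect, the same number.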